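The source may report more compounds than this note shows. Statements on the series, on what has been measured and on what is new or still open speak of the compounds shown alone.

Going by the values given here, in an ADME assay on MRC5 cells (Homo sapiens) for inhibition, with a stated time of 72 h (on this read-out higher numbers stand for an effect only at larger amounts of compound and lower numbers for an effect already at smaller amounts), compound 1 (`COc1cccc(OC)c1C(=O)Nc1c[nH]nc1C(=O)N[C@H]1CC[C@H](OC)CC1`) gives 31000 nM, the only actual number among the measured compounds. Compound 2 (`COc1cccc(OC)c1C(=O)Nc1c[nH]nc1C(=O)NCc1ccccn1`) reads > 50000 nM, which is a limit of the assay and not a number. Compound 3 (`COc1cccc(OC)c1C(=O)Nc1c[nH]nc1C(=O)NCc1ncccc1C`) reads > 50000 nM, again a limit.

Compound 4 (`COc1cc(OC)c(C(=O)Nc2c[nH]nc2C(=O)N[C@H]2CC[C@H](OC)CC2)c(OC)c1`) is not yet measured. It differs from compound 1 by methoxy in place of hydrogen on an aromatic carbon, meta to two methoxy groups and para to a large group (methoxy in place of hydrogen on an aromatic carbon).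

The measured steps bear on this change only weakly. Replacing 4-methoxycyclohexyl on the amide-type nitrogen with (pyridin-2-yl)methyl gives an at least 1.6-fold higher number from compound 1 to compound 2 (0.20 log units; that floor lies within the scatter). Replacing it with (3-methylpyridin-2-yl)methyl gives an at least 1.6-fold higher number from compound 1 to compound 3 (0.20 log units; that floor lies within the scatter). Neither step touches the ring that gains the methoxy. Among the compounds with values here, the only measured change on an aromatic carbon, methyl in place of hydrogen, is a step that the two limits leave unreadable from compound 2 to compound 3. Within the data shown here, no measured step therefore gives a size for this change, so the expectation stays anchored on compound 1 at 31000 nM, with no shift beyond the scatter in either direction. A reading at the limit of > 50000 nM in this assay, at which 2 of the 3 values shown sit, remains possible.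

The expected step is a 1.0-fold higher number from compound 1 to compound 4 (0.01 log units; within the scatter). Compound 4 is estimated at 32000 nM, with an expected range from 15000 nM to 50000 nM.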

Compound 4, half-maximal effective concentration: > 50000 nM
Compound 4: a limit, no number; the forecaster's own chance of this, stated with the estimate: 30%; at least 1.5-fold (0.19 log units) between middle value and limit.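

Going by these compounds alone, with methoxy in place of hydrogen on the aromatic carbon meta to two methoxy groups and para to a large group, this assay gives an at least 1.6-fold higher number from compound 1 to compound 4 (0.20 log units; that floor lies within the scatter), the only readable step on the ring that carries those methoxy groups. Within the data shown here, it shows that this change brought no move towards a lower number at this position, which the earlier compounds could not show, as their readable steps lay on the amide-type nitrogen and their one aromatic step could not be read. The reading of compound 4 is a limit and the printed floor lies within the scatter, so no real rise is established, and compound 4 simply joins the others at the ceiling: the limit of > 50000 nM in this assay, at which 3 of the 4 values shown sit.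

With only compound 1 carrying an actual number, the compounds shown leave open how large the effect of the added methoxy really is, and whether it would act the same way on the (pyridin-2-yl)methyl amide. They also leave open whether another group at this position, such as a fluorine atom, a hydroxyl or an amine, would give a number in this assay.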